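The source may report more compounds than this note shows. Statements on the series, on what has been measured and on what is new or still open speak of the compounds shown alone.

Compounds tested in a functional assay on HCT-116 cells (Homo sapiens) for inhibition, read by MTT assay, with a stated time of 72 h; on this read-out lower numbers stand for stronger inhibition of growth and higher numbers for weaker inhibition of growth:
- Compound 1 `O=C(COc1ccncc1-c1ccc2ccccc2c1)N1CCOCC1`: "not determined" (no result reported)
- Compound 2 `CNC(=O)/C=C/c1ccncc1-c1ccc2cc[nH]c2c1`: 10400 nM
- Compound 3 `O=C(/C=C/c1ccncc1-c1ccc2ncccc2c1)N1CCOCC1`: "not determined" (no result reported)

Going by the values given here, compound 2 holds the only number in this small set, 10400 nM, so it cannot yet be ranked against anything. Compound 4 `CCOC(=O)/C=C/c1ccncc1-c1ccc2cc[nH]c2c1` keeps the core of compound 2 and changes one end of its side chain: ethoxy in place of methylamino on a carbonyl carbon. This puts ethoxy in place of methylamino on a carbonyl carbon, turning methylcarbamoyl into ethoxycarbonyl. Among the compounds with values here, no measured pair shows what such a swap does in this assay, so no step beyond the usual scatter is expected, in either direction. The estimated step runs a 1.2-fold lower number from compound 2 to compound 4 (0.06 log units; within the scatter). The expected value for compound 4 is 9000 nM, within a wide range of 3000 nM to 30000 nM.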

Compound 4, concentration for 50% growth inhibition: 2140 nM
Estimate against measurement, compound 4: 4.2-fold (0.62 log units) above, outside the stated range (below it).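

In this assay, going by these compounds alone, the group on the carbonyl carbon clearly matters: ethoxy in place of methylamino gives the first measured step at this position (a 4.9-fold lower number from compound 2 to compound 4 (0.69 log units; beyond the scatter)). This single swap changes several things at once, as it removes a hydrogen-bond donor, adds a hydrogen-bond acceptor and adds a heavy atom. Nothing measured here explains the step. Still open, as far as these compounds go, is whether the oxygen or the extra carbon accounts for it, which ethylamino or methoxy on the same carbonyl carbon could help separate. From the compounds shown here alone, how a carboxylic acid there would compare also remains open.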